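The source may report more compounds than this note shows. Statements on the series, on what has been measured and on what is new or still open speak of the compounds shown alone.

The measured compounds:

Compound 1 `COc1cc(/C=N/NC(=O)c2cnccn2)ccc1O` gives 63.5% in a functional assay on the whole organism (strain Swiss) for inhibition, with Mus musculus as the target, read by paw edema, with stated times of 40 min and 30 min, at a dose of 100 umol/kg by the oral route; on this read-out lower numbers stand for less inhibition and higher numbers for more inhibition at the one dose given (going by the name of the read-out).
Compound 2 `O=C(N/N=C/c1ccc(-c2ccccc2)cc1)c1cnccn1` gives 47.7%.
Compound 3 `COc1ccc(/C=N/NC(=O)c2cnccn2)cc1OC` gives 49.6%.

Compound 2 stands lowest of the three numbers. Its nearest neighbour is compound 3, whose value lies within the scatter of its own, so no order between these two can be read; compound 1 lies beyond the scatter above compound 2. Within the data shown here, the only step between measured compounds that differ in one place, a number 13.9 percentage points lower from compound 1 to compound 3 (beyond the scatter), concerns a methyl on an oxygen and says nothing direct about the ring carbon that carries the phenyl.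

Compound 4 `O=C(N/N=C/c1ccccc1)c1cnccn1` differs from compound 2 in this way: hydrogen in place of phenyl on an aromatic carbon. Among the measured compounds shown here, no measured step bears on this change. For the measured compounds named here, the values of compound 2 and compound 3 show only that two different groups at this part of the ring give numbers within the scatter of each other. For compound 4, then, the step of a number 2.3 percentage points higher from compound 2 to compound 4 (within the scatter) is expected to stay within the scatter. The estimate for compound 4 is 50%, with a range from 35% to 65%.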

Compound 4, a percentage reported as inhibition, in the whole organism at one dose (the size of the read-out at that dose, not a potency): 30.5%
Compound 4: the middle estimate sits 19.5 percentage points above what was measured; the measured number lies below the stated range.
By their numbers in this assay, from the lowest: compound 4; then compounds 2 and 3 (each within the scatter of the next); then compound 1.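

In this assay, among these compounds, putting hydrogen in place of phenyl on this aromatic carbon gives a number 17.2 percentage points lower from compound 2 to compound 4 (beyond the scatter), the first direct reading of a change at this place. Among the compounds shown here, it shows that the group here is not indifferent to the read-out: with the phenyl present, compound 2 holds more inhibition at the one dose given than compound 4, which carries only hydrogen. Nothing measured on these compounds accounts for this drop.

A single pair cannot show whether the aromatic ring of the phenyl is what counts here, and a cyclohexyl ring, a tert-butyl group or a carboxylic acid on this carbon would each test that differently. Also open, on these data alone, is whether the same change would give a step of like size on a core that carries other groups.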